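This account rests on a few compounds, and the source may have more. Where it says the series, first, only, none or still open, it means among the compounds named here.

Measured so far in a functional assay on MCF7 cells (Homo sapiens) for cytotoxicity, read by MTT assay, with a stated time of 24 h; a higher number here means a weaker inhibitor, a lower number a stronger inhibitor:
- compound 1 `COC(=O)CCNC(=O)Cn1cc(C2=C(c3c[nH]c4ccccc34)C(=O)N(C)C2=O)c2ccccc21` gives 47800 nM
- compound 2 `COC(=O)[C@@H](CC(C)C)NC(=O)Cn1cc(C2=C(c3c[nH]c4ccccc34)C(=O)N(C)C2=O)c2ccccc21` gives 37400 nM
- compound 3 `COC(=O)C[C@@H](NC(=O)Cn1cc(C2=C(c3c[nH]c4ccccc34)C(=O)N(C)C2=O)c2ccccc21)C(=O)OC` gives 25800 nM

Compound 1 holds the highest of the three numbers, but the other two sit within the scatter of it: a 1.3-fold lower number from compound 1 to compound 2 (0.11 log units; within the scatter) and a 1.9-fold lower number from compound 1 to compound 3 (0.27 log units; within the scatter). The third pairing is of the same kind, a 1.4-fold lower number from compound 2 to compound 3 (0.16 log units; within the scatter), so the three amide substituents on the shared core are not told apart by this assay.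

Compound 4 `COC(=O)[C@H](NC(=O)Cn1cc(C2=C(c3c[nH]c4ccccc34)C(=O)N(C)C2=O)c2ccccc21)[C@@H](C)O` is not yet measured. Against compound 1 the difference is 2-hydroxy-1-(methoxycarbonyl)propyl in place of 2-(methoxycarbonyl)ethyl on an amide-type nitrogen. All three measured steps bear on it, since each changes only what hangs on the amide-type nitrogen or on the saturated chain carbon bound to it, and none of them left the scatter. Among the measured compounds shown here, the entering group again carries a methoxycarbonyl on the chain carbon bound to the amide-type nitrogen, as in compound 2 and compound 3, and adds a hydroxy; no measured step covers that hydroxy. The expectation is therefore no step beyond the scatter, at most a slight lowering of the number, a 1.5-fold lower number from compound 1 to compound 4 (0.17 log units; within the scatter). For compound 4 the estimate in this assay is 32000 nM, with a range from 15000 nM to 65000 nM.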

Compound 4, half-maximal inhibitory concentration: 22900 nM
Beside the measured number, compound 4's estimate is 1.4-fold (0.15 log units) above it, within the range that was stated.
By their numbers in this assay, from the lowest: compounds 4, 3, 2 and 1 (each within the scatter of the next, the first and the last beyond it).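

In this assay, among the compounds shown here, the change to 2-hydroxy-1-(methoxycarbonyl)propyl on an amide-type nitrogen gives a 2.1-fold lower number from compound 1 to compound 4 (0.32 log units; beyond the scatter) and is the first step to lie beyond the scatter, though it is a modest one. The entering group is not told apart from the other two substituents, since a 1.1-fold lower number from compound 3 to compound 4 (0.05 log units; within the scatter) and a 1.6-fold lower number from compound 2 to compound 4 (0.21 log units; within the scatter) both stay within the scatter, so only the two ends of the order, compound 4 and compound 1, separate. No measurement on hand gives a reason for this step.

For the compounds shown here, no pair separates the hydroxy from the rest of the 2-hydroxy-1-(methoxycarbonyl)propyl group, so its own contribution stays open. All four compounds carry a methoxycarbonyl, which leaves open how the number responds to a carboxylic acid in its place, or to an amine on the saturated chain carbon bound to the amide-type nitrogen.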